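Aryl substituent on the triazole nitrogen and cytotoxicity

The source may hold more compounds than are shown below. What is called first, only, known or untested is meant among the compounds shown, and "the series" means these compounds.

Measured compounds:
- compound 1, `Oc1cc(C(F)(F)F)ccc1-c1nc(-c2ccccc2O)n(-c2ccc(OC(F)(F)F)cc2)n1`: 92.5%
- compound 2, `COc1ccccc1-n1nc(-c2ccc(C(F)(F)F)cc2O)nc1-c1ccccc1O`: 96.2%
- compound 3, `Oc1cc(C(F)(F)F)ccc1-c1nc(-c2ccccc2O)n(-c2cccc(Cl)c2)n1`: 100%

All three compounds were tested in a functional assay on PC-12 cells (Rattus norvegicus) for cytotoxicity, read by MTT assay, with stated times of 2 h and 24 h, tested at 10 uM; on this read-out higher numbers stand for a stronger effect at the one concentration tested and lower numbers for a weaker effect. Compound 3 holds the highest of the three numbers, but its steps to the other two, a number 3.8 percentage points higher from compound 2 to compound 3 (within the scatter) and a number 7.5 percentage points higher from compound 1 to compound 3 (within the scatter), both lie within the scatter, so no order among the three is established.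

Compound 4, `Cc1cc(C)cc(-n2nc(-c3ccc(C(F)(F)F)cc3O)nc2-c2ccccc2O)c1`, is not yet measured. It differs from compound 3 as follows: 3,5-dimethylphenyl in place of 3-chlorophenyl on an aromatic nitrogen.

Among the compounds with values here, two measured steps bear on this change, since both alter the group on the same aromatic nitrogen: a number 7.5 percentage points higher from compound 1 to compound 3 (within the scatter) and a number 3.8 percentage points higher from compound 2 to compound 3 (within the scatter). Neither step moves the read-out beyond the scatter, and the third step on this position, a number 3.7 percentage points higher from compound 1 to compound 2 (within the scatter), is likewise within it. For compound 4 the same kind of exchange is therefore expected to give no step beyond the scatter, the estimated step being a number 4 percentage points lower from compound 3 to compound 4 (within the scatter). Compound 4 is expected to give 96% in this assay, with a range from 85% to 105%.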

Compound 4, a percentage reported as activity, at one concentration (the size of the read-out at that concentration, not a potency): 105%
Compound 4: the middle estimate sits 9 percentage points below what was measured; low and high end bracket the measured number.
By their numbers in this assay, from the lowest: compounds 1, 2, 3 and 4 (each within the scatter of the next, the first and the last beyond it).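

In this assay, within the data shown here, the step of a number 12.5 percentage points higher from compound 1 to compound 4 (beyond the scatter) is the first at this aromatic nitrogen to lie beyond the scatter, so exchanging one aryl group for another here can move the read-out, if only modestly. Placing 3,5-dimethylphenyl in place of 3-chlorophenyl gives a number 5 percentage points higher from compound 3 to compound 4 (within the scatter) and placing it in place of 2-methoxyphenyl gives a number 8.8 percentage points higher from compound 2 to compound 4 (within the scatter) and thus neither exchange separates compound 4 from its partner. Among these compounds, nothing at hand accounts for the one step beyond the scatter.

Every group shown at this position is a substituted phenyl, so the effect of a butyl chain, an aminoethyl chain or a phenyl ring bearing a carboxylic acid in its place remains open. The read-out also stands at a single concentration, which leaves the potency of all four compounds open.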